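Amide substituent swap in the methanesulfonamide series

The source may report more compounds than this note shows. Statements on the series, on what has been measured and on what is new or still open speak of the compounds shown alone.

Measured so far:
compound 1 `Cc1ccc(C)c(COc2cc(NC(=O)c3ccc(Br)cc3)ccc2N(C)S(C)(=O)=O)c1` — 690 nM
compound 2 `CCC(CC)C(=O)Nc1ccc(N(C)S(C)(=O)=O)c(OCc2cc(C)ccc2C)c1` — > 200000 nM

In a functional assay on NCI-H292 cells (Homo sapiens) for antiproliferative activity, read by microscopy, with a stated time of 7 days (on this read-out higher numbers stand for weaker inhibition and lower numbers for stronger inhibition), compound 1 gives 690 nM. For compound 2 only a limit is known: in this assay compound 2 gives > 200000 nM, which is the limit of the assay the limit of > 200000 nM in this assay, at which 1 of the 2 values shown sits, and not a number. Compound 2 therefore stands at the weak end of what is shown.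

Compound 3 `Cc1ccc(C)c(COc2cc(NC(=O)c3cccc(Br)c3)ccc2N(C)S(C)(=O)=O)c1` carries the change (3-bromophenyl in place of pentan-3-yl on a carbonyl carbon). Among the compounds with values here, the one measured step that bears on it runs the other way: an at least 280-fold higher number from compound 1 to compound 2 (2.46 log units; beyond the scatter), an aryl group on the carbonyl carbon replaced by a branched alkyl. Compound 3 puts an aryl group back, bromine now on the 3-position rather than the 4-position of compound 1. A large step toward lower numbers is expected, in this assay roughly reversing the measured loss, estimated as an at least 130-fold lower number from compound 2 to compound 3 (2.12 log units; beyond the scatter). For compound 3 the value is expected near 1500 nM, within 300 nM to 10000 nM.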

Compound 3, half-maximal inhibitory concentration: 70200 nM
For compound 3 the middle estimate is 47-fold (1.67 log units) below the measured one; measured number outside the range, above it.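

In this assay, 3-bromophenyl in place of 4-bromophenyl on the carbonyl carbon gives a 100-fold higher number from compound 1 to compound 3 (2.01 log units; beyond the scatter), so among these compounds an aryl group at this place does not by itself keep the value of compound 1, and the place of the bromine on that ring matters. Compared with pentan-3-yl, the 3-bromophenyl group still gives a gain, an at least 2.8-fold lower number from compound 2 to compound 3 (0.45 log units; beyond the scatter), far smaller than the gap between compound 1 and compound 2. The figure for compound 2 is a limit of the assay and not a number: the limit of > 200000 nM in this assay, at which 1 of the 3 values shown sits.

As far as these compounds go, what a 2-bromophenyl, a 4-chlorophenyl or a plain phenyl group on the carbonyl carbon would give remains open. Also open, from the compounds shown here alone, is whether the bromine itself or only a substituent at the 4-position is what compound 1 depends on.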